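The source may report more compounds than this note shows. Statements on the series, on what has been measured and on what is new or still open speak of the compounds shown alone.

Measured compounds and their numbers in an assay for inhibition of Myeloperoxidase (Homo sapiens), read by Amplex Red, with stated times of 10 min and 15 min; on this read-out lower numbers stand for stronger inhibition and higher numbers for weaker inhibition:

Compound 1: `Nc1cc(OCc2ccccc2F)c2nn[nH]c2n1` — 30 nM
Compound 2: `Nc1cc(OCc2ccccc2Cl)c2nn[nH]c2n1` — 26 nM

On the numbers in hand, compound 2 gives the lowest of two numbers in this assay, with compound 1 as its nearest neighbour; the step of a 1.2-fold lower number from compound 1 to compound 2 (0.06 log units; within the scatter) is within the scatter, so the two compounds cannot be ordered against each other.

The step to compound 3, `CS(=O)(=O)c1ccccc1COc1cc(N)nc2[nH]nnc12`, is methylsulfonyl in place of chloro on an aromatic carbon. Going by the values given here, the only measured step on the shared core, a 1.2-fold lower number from compound 1 to compound 2 (0.06 log units; within the scatter), exchanges one halogen for another and shows no shift beyond the scatter. Among the compounds with values here, no measured pair exchanges a halogen for a group of four heavy atoms with two hydrogen-bond acceptors, so the size of the present step cannot be read from the series. The expectation is therefore a step larger than the halogen exchange, wide in its uncertainty, and on balance toward a higher number, as a 2.7-fold higher number from compound 2 to compound 3 (0.43 log units; beyond the scatter). For compound 3 in this assay the estimate is 70 nM, with a range from 15 nM to 400 nM.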

Compound 3, half-maximal inhibitory concentration: 720 nM
The estimate for compound 3 lay 10-fold (1.01 log units) below the measured number; measured number above the stated range.
By their numbers in this assay, from the lowest: compounds 2 and 1 (each within the scatter of the next); then compound 3.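

At this position, an aromatic carbon ortho to a large group, the earlier halogen exchange left open whether the group matters at all; in this assay methylsulfonyl now shows that it does, with a 28-fold higher number from compound 2 to compound 3 (1.44 log units; beyond the scatter) in place of chloro. The step in place of fluoro points the same way, at a 24-fold higher number from compound 1 to compound 3 (1.38 log units; beyond the scatter) on the same read-out, so the rise does not depend on which of the two halogens leaves. The position therefore accepts chloro and fluoro with no difference beyond the scatter but does not accept every substituent, though nothing at hand bears on the origin of this rise.

Methylsulfonyl differs from the halogens in heavy atoms and in hydrogen-bond acceptors at once, and the compounds shown do not separate these two differences. Open, as far as these compounds go, is where groups such as methyl, methoxy, nitrile, an amine or a carboxylic acid would fall at this place, and so whether the rise belongs to methylsulfonyl alone or to a wider set of groups.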